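Adding a methoxy group to compound 1

The compounds below may be only part of what the source reports. "The series", "measured", "known", "first", "only" and "open" are said of these compounds alone.

Compound 1 (`S=C(N/N=C/c1cccs1)Nc1ccccc1`) gives > 100000 nM (a limit, not a number)
Compound 2 (`S=C(N/N=C/c1cccs1)Nc1cccc2ccccc12`) gives 82400 nM

Within the data shown here, both compounds have been tested in an ADME assay on HaCaT cells (Homo sapiens) for inhibition, read by sulforhodamine B assay, with a stated time of 48 h (on this read-out lower numbers stand for stronger inhibition of growth and higher numbers for weaker inhibition of growth), and they are the only measurements so far. Compound 1 has no exact position on this scale: it stands only at a limit (the limit of > 100000 nM in this assay, at which 1 of the 2 values shown sits). Compound 2 does give a number in this assay, namely 82400 nM, and it remains in the weak part of the range.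

The compound still to be measured is compound 3 (`COc1ccc(NC(=S)N/N=C/c2cccs2)cc1`). It keeps the core of compound 1 and carries methoxy in place of hydrogen on an aromatic carbon, para to a large group (methoxy in place of hydrogen on an aromatic carbon). Among the measured compounds shown here, no measured pair yet shows what such a change does in this assay, so only a modest expectation is possible. The expected change is small, an at least 1.2-fold lower number from compound 1 to compound 3 (0.09 log units; that floor lies within the scatter), with any shift toward slightly stronger inhibition of growth and probably none beyond the scatter. Compound 3 may also report only a limit. For compound 3 the estimated value is 80000 nM (expected range 35000 nM to 130000 nM).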

Compound 3, concentration for 50% growth inhibition: > 100000 nM
Compound 3: only a limit was reported (the forecaster's own chance of this, stated with the estimate: 50%); at least 1.2-fold (0.09 log units) between middle value and limit.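

In this assay compound 3 gives > 100000 nM as a limit and not a number, and compound 1 also stands only at a limit, so no step can be read between the two: the limit of > 100000 nM in this assay, at which 2 of the 3 values shown sit.

The compounds shown leave open whether methoxy in place of hydrogen on an aromatic carbon changes the value in this assay at all, and in which direction.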